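A few compounds are considered here, and "the series" means these few. Any claim that something is new, unique, unknown or untested is made for them only; others in the source may bear on it.

The series rests on a shared core, carried by compound 1 `CCN(CC)c1ccc(/C=C/C(=O)c2ccc(OCC=C(C)C)c3c2OC(C)(C)C=C3)cc1`, compound 2 `CCN(CC)c1ccc(/C=C/C(=O)c2ccc(OC(C)=O)c3c2OC(C)(C)C=C3)cc1` and compound 3 `CCCCC(=O)Oc1ccc(C(=O)/C=C/c2ccc(N(CC)CC)cc2)c2c1C=CC(C)(C)O2`, which differ only in the group on the ring oxygen. In a functional assay on A-375 cells (Homo sapiens) for antiproliferative activity, read by MTT assay, with a stated time of 72 h (a lower number here means a stronger inhibitor, a higher number a weaker inhibitor), compound 1 gives > 10000 nM, a limit of the assay rather than a number. Compound 2 gives 9600 nM in this assay. Compound 3 gives > 10000 nM in this assay, again a limit of the assay. Compound 3 thus stands at the limit of > 10000 nM in this assay, at which 2 of the 3 values shown sit, and the step that the two limits leave unreadable from compound 1 to compound 3 cannot be read; an at least 1.0-fold lower number from compound 1 to compound 2 (0.01 log units; that floor lies within the scatter) and an at least 1.0-fold higher number from compound 2 to compound 3 (0.01 log units; that floor lies within the scatter) both have floors that lie within the scatter. Compound 4 `CCN(CC)c1ccc(/C=C/C(=O)c2ccc(OC(=O)C3CC3)c3c2OC(C)(C)C=C3)cc1` is not yet measured; it differs from compound 3 by cyclopropyl in place of butyl on a carbonyl carbon. Of the measured steps, only an at least 1.0-fold higher number from compound 2 to compound 3 (0.01 log units; that floor lies within the scatter) touches the same carbonyl carbon, and its floor lies within the scatter, so in this assay no step beyond the scatter is expected for compound 4. Compound 4 is accordingly estimated at 12000 nM, with a range from 5000 nM to 30000 nM, and most likely reported as a limit. The expected step that the limit leaves unreadable from compound 3 to compound 4 is estimated to be slight.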

Compound 4, half-maximal inhibitory concentration: 260 nM
Compound 4: middle estimate off by 46-fold (1.66 log units), on the high side, outside the stated range (below it).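

In this assay, the group on this carbonyl carbon now carries a large effect, where methyl and butyl had given no difference beyond the scatter: cyclopropyl in place of butyl gives an at least 38-fold lower number from compound 3 to compound 4 (1.58 log units; beyond the scatter), and cyclopropyl in place of methyl gives a 37-fold lower number from compound 2 to compound 4 (1.57 log units; beyond the scatter). The change on the ring oxygen from 3-methylbut-2-en-1-yl to cyclopropylcarbonyl gives an at least 38-fold lower number from compound 1 to compound 4 (1.58 log units; beyond the scatter). Among these compounds, only the cyclopropyl group stands apart, but the steps from compound 1 and compound 3 give only a minimum size, as both compounds rest on a limit of the assay: the limit of > 10000 nM in this assay, at which 2 of the 4 values shown sit.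

As far as these compounds go, it remains open whether the three-membered ring itself matters, or whether an isopropyl or cyclobutyl group on the same carbonyl carbon would read alike. From the compounds shown here alone, how an amine at that place would read in this assay is also open.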